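The source may report more compounds than this note shows. Statements on the series, on what has been measured and on what is new or still open speak of the compounds shown alone.

Compounds measured in a functional assay on CCRF-CEM cells (Homo sapiens) for inhibition, read by sulforhodamine B assay, with a stated time of 48 h, tested at 10 uM; on this read-out lower numbers stand for less inhibition and higher numbers for more inhibition at the one concentration tested (going by the name of the read-out):

compound 1, `c1ccc2c(-c3cn4ccnc4c(-c4ccc5ncn(C6CCCCC6)c5c4)n3)cccc2c1`, 17.5%
compound 2, `CC(=O)c1ccc(-c2cn3ccnc3c(-c3ccc4ncn(C5CCCCC5)c4c3)n2)cc1`, 1.1%
compound 3, `COc1ccccc1-c1cn2ccnc2c(-c2ccc3ncn(C4CCCCC4)c3c2)n1`, 17.4%

Of the compounds shown here, three sharing one core have been measured in this assay, and they differ only in the aryl group attached to the core. Compound 3 stands second highest of the three numbers; its nearest neighbour is compound 1, which lies within the scatter of it, and its furthest is compound 2, which lies beyond the scatter below it.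

The steps among the measured compounds are of two kinds. Replacing naphthalen-1-yl by 2-methoxyphenyl gives a number 0.1 percentage points lower from compound 1 to compound 3 (within the scatter), a change within the scatter. Replacing naphthalen-1-yl by 4-acetylphenyl gives a number 16.4 percentage points lower from compound 1 to compound 2 (beyond the scatter), and replacing 4-acetylphenyl by 2-methoxyphenyl gives a number 16.3 percentage points higher from compound 2 to compound 3 (beyond the scatter), both modest steps beyond the scatter.

Compound 4, `c1csc(-c2cn3ccnc3c(-c3ccc4ncn(C5CCCCC5)c4c3)n2)c1`, has not yet been measured. It differs from compound 3 as follows: thiophen-2-yl in place of 2-methoxyphenyl on an aromatic carbon. Among the measured compounds shown here, no measured step exchanges a six-membered aryl group for a five-membered one, so the nearest guidance comes from the steps above, which show that swapping the aryl group moved this assay either within the scatter or by a modest amount. A step of about a number 5.4 percentage points lower from compound 3 to compound 4 (within the scatter) is therefore expected for compound 4, with the direction uncertain. Compound 4 is estimated at 12%, within a range from 0% to 28%.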

Compound 4, a percentage reported as inhibition, at one concentration (the size of the read-out at that concentration, not a potency): 46.4%
The estimate for compound 4 lay 34.4 percentage points below the measured number; the measured number lies above the stated range.
By their numbers in this assay, from the lowest: compound 2; then compounds 3 and 1 (each within the scatter of the next); then compound 4.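

Thiophen-2-yl is the first group at this position on the shared core to bring a clear rise in this assay, with a number 29 percentage points higher from compound 3 to compound 4 (beyond the scatter) and a number 28.9 percentage points higher from compound 1 to compound 4 (beyond the scatter) as well as a number 45.3 percentage points higher from compound 2 to compound 4 (beyond the scatter) in the comparison with the lowest of the earlier compounds. Among the earlier compounds, naphthalen-1-yl and 2-methoxyphenyl gave numbers within the scatter of each other and only 4-acetylphenyl stood apart, on the low side, so those three gave no sign that this position could reach a number so far above them. Compound 4 is also the only one shown with a five-membered aromatic ring here, and it stands beyond the scatter of all three six-membered-ring-bearing compounds, though nothing available bears on why this exchange raises the number.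

As far as these compounds go, what remains open is whether the rise goes with the five-membered ring, with the sulfur or with the attachment through the carbon next to it, which furan-2-yl, thiophen-3-yl or an unsubstituted phenyl would begin to separate. A read-out at a single concentration also leaves open how compound 4 would behave across a range of concentrations.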